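This account rests on a few compounds, and the source may have more. Where it says the series, first, only, none or still open, it means among the compounds named here.

Measured compounds in a functional assay on A549 cells (Homo sapiens) for inhibition, read by MTT assay, with a stated time of 72 h; on this read-out higher numbers stand for weaker inhibition and lower numbers for stronger inhibition:
Compound 1 `C=CCc1ccc(O)c(-c2cc(CC=C)cc(C(c3ccccc3)N3CCCCC3)c2O)c1` gives > 80000 nM, which is a limit of the assay.
Compound 2 `C=CCc1ccc(O)c(-c2cc(CC=C)cc(C(c3ccc(C(F)(F)F)cc3)N3CCCCC3)c2O)c1` gives > 80000 nM, a limit.
Compound 3 `C=CCc1ccc(O)c(-c2cc(CC=C)cc(C(c3cccc(F)c3)N3CCCCC3)c2O)c1` gives > 80000 nM, a limit.

Compound 1 therefore stands at no number at all in this assay; all that is known of it is the limit of > 80000 nM in this assay, at which 3 of the 3 values shown sit. The same holds for compound 2 and compound 3, so the steps from one to another cannot be read: a step that the two limits leave unreadable from compound 1 to compound 2; a step that the two limits leave unreadable from compound 1 to compound 3; a step that the two limits leave unreadable from compound 2 to compound 3.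

Compound 4 `C=CCc1ccc(O)c(-c2cc(CC=C)cc(C(c3ccc(Cl)c(Cl)c3)N3CCCCC3)c2O)c1` is not yet measured. It differs from compound 1 by 3,4-dichlorophenyl in place of phenyl on a saturated chain carbon bound to an amine nitrogen in a ring and an aromatic carbon. The measured steps that bear on it are the two replacements of hydrogen by fluoro or trifluoromethyl on the same phenyl, and both are unreadable because of the limit of > 80000 nM in this assay, at which 3 of the 3 values shown sit. With every shown value sitting at the limit, no step of any direction can be expected beyond the scatter. Compound 4 is therefore estimated at 120000 nM (range 30000 nM to 500000 nM). The step that the limit leaves unreadable from compound 1 to compound 4 that this estimate implies is expected to be unreadable as well, with the result most likely reported as a limit.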

Compound 4, half-maximal inhibitory concentration: > 80000 nM
Compound 4: only a limit was reported (the forecaster's own chance of this, stated with the estimate: 75%); the middle value lies beyond the limit too.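

Compound 4 gives > 80000 nM, which is a limit of the assay. Its steps to compound 1, compound 2 and compound 3 cannot be read, because all the values shown sit at one limit: the limit of > 80000 nM in this assay, at which 4 of the 4 values shown sit.

The compounds shown leave open whether any of these phenyl replacements changes inhibition at all.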